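Trifluoromethyl to hydrogen on a triazole-linked phenyl ring

A few compounds are considered here, and "the series" means these few. Any claim that something is new, unique, unknown or untested is made for them only; others in the source may bear on it.

In a functional assay on SW480 cells (Homo sapiens) for cytotoxicity, read by MTT assay, with a stated time of 4 days (on this read-out higher numbers stand for weaker inhibition and lower numbers for stronger inhibition), the measured compounds stand as follows.
Compound 1, `C=C1C[C@]23C[C@@]1(O)CC[C@H]2c1cc(Br)c(O)c(C)c1[C@@H]3Cn1cc(-c2ccccc2)nn1`, gives > 20000 nM.
Compound 2, `C=C1C[C@]23C[C@@]1(O)CC[C@H]2c1ccc(O)c(C)c1[C@@H]3Cn1cc(-c2ccc(C(F)(F)F)cc2)nn1`, gives > 20000 nM.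
Compound 3, `C=C1C(=O)[C@]23C[C@@]1(O)CC[C@H]2c1ccc(O)c(C)c1[C@@H]3Cn1cc(-c2ccc(C)cc2)nn1`, gives 330 nM.

Compound 2 stands at a limit of this assay, not at a number. Compound 1 likewise reports only a limit. Together these two make up (the limit of > 20000 nM in this assay, at which 2 of the 3 values shown sit). Going by the values given here, compound 3 alone gives a number, but it differs from compound 2 in more than one place, so no single step connects the two; its value simply shows that members of this family can register in this assay.

Compound 4, `C=C1C[C@]23C[C@@]1(O)CC[C@H]2c1ccc(O)c(C)c1[C@@H]3Cn1cc(-c2ccccc2)nn1`, is the unmeasured member. It arises from compound 2 by one change: hydrogen in place of trifluoromethyl on an aromatic carbon. Among the compounds with values here, no measured pair shows this step on its own, and compound 1, which also carries a phenyl ring on the triazole, sits at the limit. Compound 4 is therefore expected to remain at the limit, and the step of a number no higher from compound 2 to compound 4 (the limit leaves the size open) is expected to be none beyond the scatter. For compound 4 the estimate is 20000 nM, with a range from 6000 nM to 50000 nM.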

Compound 4, half-maximal inhibitory concentration: > 20000 nM
Compound 4: no number, only a limit (the forecaster's own chance of this, stated with the estimate: 70%); the middle value lies on the limit itself.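

In this assay compound 4 gives > 20000 nM, a limit and not a number. Its steps from compound 1 and compound 2, which also stand at limits, cannot be read. The compounds shown leave open whether hydrogen in place of trifluoromethyl or bromo changes cytotoxicity at all.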